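A few compounds are considered here, and "the series" means these few. Any claim that something is new, unique, unknown or untested is made for them only; others in the source may bear on it.

Measured so far in a functional assay on HT-29 cells (Homo sapiens) for cytotoxicity, read by sulforhodamine B assay, with a stated time of 48 h; a higher number here means a weaker inhibitor, a lower number a stronger inhibitor:
compound 1, `CCn1cc(-c2nc3ccccc3[nH]2)c(=O)c2cc(F)c(N3CCNCC3)cc21`: > 10000 nM
compound 2, `CCn1cc(-c2nc3ccc(Cl)cc3[nH]2)c(=O)c2cc(F)c(N3CCNCC3)cc21`: 4700 nM
compound 3, `CCn1cc(-c2nc3ccc(N)cc3[nH]2)c(=O)c2cc(F)c(N3CCNCC3)cc21`: > 10000 nM

Compound 3 stands at a limit of this assay, > 10000 nM, not at a number. Compound 1 likewise returns only a limit, > 10000 nM. Among the measured compounds shown here, compound 2 is the one compound of the three with a number, 4700 nM. The evidence on the measured steps is the limit of > 10000 nM in this assay, at which 2 of the 3 values shown sit. For the measured compounds named here, the step of an at least 2.1-fold lower number from compound 1 to compound 2 (0.32 log units; beyond the scatter) is therefore the only one read against a number; the step of an at least 2.1-fold higher number from compound 2 to compound 3 (0.32 log units; beyond the scatter) also reaches that number; the step that the two limits leave unreadable from compound 1 to compound 3 runs between two limits.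

Compound 4, `CCn1cc(-c2nc3ccc(N)cc3[nH]2)c(=O)c2cc(F)c(N3CCN(C)CC3)cc21`, differs from compound 3 at a place none of the three measured steps touches: methyl in place of hydrogen on an amine nitrogen in a ring. All three measured steps alter a substituent on an aromatic carbon of the group attached to the core, while the ring nitrogen is unchanged in compounds 1, 2 and 3. Going by the values given here, no measured step therefore bears on the change from compound 3 to compound 4, and no step beyond the scatter is expected in this assay; the expected step is a step that the limit leaves unreadable from compound 3 to compound 4. Compound 4 is estimated at 15000 nM, within 5000 nM to 50000 nM, most probably again returned as a limit.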

Compound 4, half-maximal inhibitory concentration: > 10000 nM
Compound 4 ended at the assay's limit (the forecaster's own chance of this, stated with the estimate: 70%); the middle value does not contradict the limit.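

No step can be read between compound 3 and compound 4 in this assay, as each returns only a limit: the limit of > 10000 nM in this assay, at which 3 of the 4 values shown sit.

The compounds shown leave open what 4-methylpiperazin-1-yl in place of piperazin-1-yl does in this assay to a compound that returns a number, such as compound 2.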